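Swapping the benzyl ring substituent on a pyrazolopyrimidine core

The source may report more compounds than this note shows. Statements on the series, on what has been measured and on what is new or still open speak of the compounds shown alone.

Compound 2 `CCN(Cc1ccc(C)cc1)c1cc(C)nc2c(-c3cnc(N(C)C)cc3C)c(C)nn12` and compound 1 `CCN(Cc1ccccc1C)c1cc(C)nc2c(-c3cnc(N(C)C)cc3C)c(C)nn12` share a core and differ only in the aromatic ring on a saturated chain carbon bound to a nitrogen on an aromatic ring. In an assay on CHO cells for binding affinity to corticotropin-releasing factor receptor 1 (Homo sapiens) (on this read-out lower numbers stand for stronger inhibition and higher numbers for weaker inhibition), compound 2 gives 2.3 nM, and compound 1 gives 2.4 nM. The step from compound 1 to compound 2 is a 1.0-fold lower number from compound 1 to compound 2 (0.02 log units; within the scatter), so compound 2 stands alongside compound 1 rather than apart from it. Compound 3 `CCN(Cc1ccccc1F)c1cc(C)nc2c(-c3cnc(N(C)C)cc3C)c(C)nn12` is not yet measured. It differs from compound 2 by 2-fluorophenyl in place of 4-methylphenyl on a saturated chain carbon bound to a nitrogen on an aromatic ring. Going by the values given here, the only measured step that bears on this position is a 1.0-fold lower number from compound 1 to compound 2 (0.02 log units; within the scatter), which shows that a change of the ring substituent there left the number essentially unchanged. A step within the scatter is therefore expected for compound 3 in this assay. Compound 3 is expected to give 3 nM, with a range from 1 nM to 9 nM. That estimate means an expected step of a 1.3-fold higher number from compound 2 to compound 3 (0.12 log units; within the scatter).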

Compound 3, inhibition constant: 3.4 nM
For compound 3 the middle estimate is 1.1-fold (0.05 log units) below the measured one, and the stated range covers the measured number.
By their numbers in this assay, from the lowest: compounds 2, 1 and 3 (each within the scatter of the next).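

Compound 3 brings a fluorine onto the benzyl ring, which neither earlier compound carried, and in this assay the change from 4-methylbenzyl to 2-fluorobenzyl gives a 1.5-fold higher number from compound 2 to compound 3 (0.17 log units; within the scatter), so a change of both the substituent and its place on the ring still leaves the two compounds alongside each other. Read against compound 1, the change is fluoro in place of methyl on an aromatic carbon, and it gives a 1.4-fold higher number from compound 1 to compound 3 (0.15 log units; within the scatter), so among these three compounds methyl and fluoro are not told apart at this position.

Open, going by these compounds, is whether a methoxy group, a trifluoromethyl group, an amine or a carboxylic acid on this ring would also stay within the scatter. Also open, on these data alone, is whether a pyridine ring could take the place of the phenyl ring. Nothing given here accounts for these results.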